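The source may report more compounds than this note shows. Statements on the series, on what has been measured and on what is new or still open speak of the compounds shown alone.

Compound 2 `C#CCNC(=O)/C(C)=C(\C)c1ccc(OC)cc1` gives 150 mg/kg in a toxicity assay on the whole organism (strain Icem-CET (SPF Caw)) for cytotoxicity, with Mus musculus as the target (a lower number here means that less compound is needed, a higher number that more compound is needed for the effect), the lowest of the three numbers in hand, though all three lie within the scatter of one another. Compound 3 `C=CCNC(=O)/C(C)=C(\C)c1ccc(OC)cc1` gives 200 mg/kg and compound 1 `COc1ccc(/C(C)=C(\C)C(=O)NC2CC2)cc1` gives 250 mg/kg; the steps of a 1.3-fold higher number from compound 2 to compound 3 (0.12 log units; within the scatter), a 1.7-fold lower number from compound 1 to compound 2 (0.22 log units; within the scatter) and a 1.3-fold lower number from compound 1 to compound 3 (0.10 log units; within the scatter) are each within the scatter. Compound 4 `C#CCNC(=O)/C(C)=C(\C)c1ccc(Cl)cc1` differs from compound 2 by chloro in place of methoxy on an aromatic carbon. Among the compounds with values here, every measured step concerns the group on the amide-type nitrogen; none touches the aromatic carbon para to a large group, so no measured step bears directly on this change. No step beyond the scatter is therefore expected, no change at the digits printed from compound 2 to compound 4 (within the scatter). For compound 4 the estimate in this assay is 150 mg/kg, within 80 mg/kg to 300 mg/kg.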

Compound 4, dose for half-maximal effect: 60 mg/kg
Estimate against measurement, compound 4: 2.5-fold (0.40 log units) above; measured number outside the range, below it.
By their numbers in this assay, from the lowest: compound 4; then compounds 2, 3 and 1 (each within the scatter of the next).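

In this assay, chloro in place of methoxy on the aromatic carbon gives a 2.5-fold lower number from compound 2 to compound 4 (0.40 log units; beyond the scatter). Among these compounds, this is the only step beyond the scatter, as every step among the groups on the amide-type nitrogen stays within it. No measurement shown explains this step. The compounds shown leave open whether the step follows from chloro itself or from the loss of methoxy, which a methyl or an amine at this position could help separate. On these data alone, whether it carries over with allyl or cyclopropyl on the nitrogen also remains open.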